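Replacing Furan with Cyclopentene on Compound 2

This account rests on a few compounds, and the source may have more. Where it says the series, first, only, none or still open, it means among the compounds named here.

Three related compounds have been measured in a functional assay on MT2 cells (Homo sapiens) for cytotoxicity, read by MTT assay; on this read-out higher numbers stand for lower toxicity in this test and lower numbers for higher toxicity in this test. Compound 1 (`CC(C)=CCOc1cccc(Nc2nccs2)c1`) gives 23000 nM and compound 2 (`Clc1ccc(Nc2nccs2)cc1OCc1ccoc1`) gives 26000 nM, two numbers within the scatter of each other. Compound 3 (`N#Cc1ccc(Nc2nccs2)cc1OCc1ccsc1`) gives a clearly lower 1100 nM. Compound 4 (`Clc1ccc(Nc2nccs2)cc1OCC1=CCCC1`) has cyclopent-1-en-1-yl in place of the furan-3-yl of compound 2, on a saturated chain carbon bound to an oxygen on an aromatic ring: cyclopent-1-en-1-yl in place of furan-3-yl on a saturated chain carbon bound to an oxygen on an aromatic ring. Among the compounds with values here, no measured pair shows this swap directly, so no step beyond the scatter is expected in this assay. The estimated step is a 1.3-fold lower number from compound 2 to compound 4 (0.11 log units; within the scatter). For compound 4 the expected value is 20000 nM, with a likely range of 8000 nM to 45000 nM.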

Compound 4, half-maximal cytotoxic concentration: 15000 nM
Estimate against measurement, compound 4: 1.3-fold (0.12 log units) above, within the range that was stated.
By their numbers in this assay, from the lowest: compound 3; then compounds 4, 1 and 2 (each within the scatter of the next).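

In this assay, within the data shown here, putting cyclopent-1-en-1-yl in place of furan-3-yl gives a 1.7-fold lower number from compound 2 to compound 4 (0.24 log units; within the scatter), the first direct reading of this swap. On the core of compound 2, a non-aromatic ring of carbon only, with no hydrogen-bond acceptor, therefore reads the same within the scatter as the aromatic ring containing oxygen. Nothing measured here gives a reason for this match.

From the compounds shown here alone, whether an amine, a cyclopentyl ring or a longer chain on this carbon would read the same remains open. So does whether this swap would read the same on the core of compound 3.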